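This account rests on a few compounds, and the source may have more. Where it says the series, first, only, none or still open, it means among the compounds named here.

Measured so far in a functional assay on RPMI 8402 cells (Homo sapiens) for cytotoxicity; a higher number here means a weaker inhibitor, a lower number a stronger inhibitor:
compound 1 `COc1ccc(-c2ccc3[nH]c(-c4ccc5[nH]c(-c6ccc7[nH]cnc7c6)nc5c4)nc3c2)cc1` — 90 nM
compound 2 `c1ccc(-c2ccc3[nH]c(-c4ccc5[nH]c(-c6ccc7[nH]cnc7c6)nc5c4)nc3c2)cc1` — 90 nM
compound 3 `c1ccc2c(-c3ccc4[nH]c(-c5ccc6[nH]c(-c7ccc8[nH]cnc8c7)nc6c5)nc4c3)cccc2c1` — 2100 nM

Compound 3 stands at the highest number of the three. Compound 1 and compound 2 are within the scatter of each other, as no change at the digits printed from compound 1 to compound 2 (within the scatter) shows. The steps to compound 3 are large: a 23-fold higher number from compound 1 to compound 3 (1.37 log units; beyond the scatter) and a 23-fold higher number from compound 2 to compound 3 (1.37 log units; beyond the scatter).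

Compound 4 `c1ccc2cc(-c3ccc4[nH]c(-c5ccc6[nH]c(-c7ccc8[nH]cnc8c7)nc6c5)nc4c3)ccc2c1` is not yet measured. The change is naphthalen-2-yl in place of naphthalen-1-yl on an aromatic carbon. Going by the values given here, no measured step exchanges one naphthyl attachment for the other, so the two steps that bear on it do so only indirectly: they show that naphthalen-1-yl in compound 3 sits far above phenyl in compound 2 and 4-methoxyphenyl in compound 1 in this assay. Because a 23-fold higher number from compound 2 to compound 3 (1.37 log units; beyond the scatter) is large, a shift back toward the numbers of compound 1 and compound 2 is expected for compound 4, but a partial one, with wide uncertainty. The expected step is a 6.0-fold lower number from compound 3 to compound 4 (0.78 log units; beyond the scatter). Compound 4 is estimated at 350 nM, in the range 80 nM to 1600 nM.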

Compound 4, half-maximal inhibitory concentration: 80 nM
Beside the measured number, compound 4's estimate is 4.4-fold (0.64 log units) above it; the range from low to high includes it.
By their numbers in this assay, from the lowest: compounds 4, 1 and 2 (each within the scatter of the next); then compound 3.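

In this assay, the large step sits in the attachment point of the naphthalene alone (a 26-fold lower number from compound 3 to compound 4 (1.42 log units; beyond the scatter)), with the same atoms joined differently, so carrying a naphthyl group at this aromatic carbon does not by itself bring the number of compound 3. Naphthalen-2-yl lies within the scatter of both single-ring groups (a 1.1-fold lower number from compound 2 to compound 4 (0.05 log units; within the scatter); a 1.1-fold lower number from compound 1 to compound 4 (0.05 log units; within the scatter)), so in these compounds the second aromatic ring alone brings no step beyond the scatter. Nothing at hand explains why the two naphthyl attachments differ.

The compounds shown leave open whether an amine or a carboxylic acid on naphthalen-2-yl would stay within the scatter of compound 4. As far as these compounds go, it is also open whether a longer chain in place of the methoxy group of compound 1 would do the same.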